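The source may hold more compounds than are shown below. What is called first, only, known or untested is meant among the compounds shown, and "the series" means these compounds.

Of the compounds shown here, three built on one shared core have been measured in a functional assay on HeLa S3 cells (Homo sapiens) for antiproliferative activity, read by XTT assay, with a stated time of 72 h (on this read-out higher numbers stand for weaker inhibition and lower numbers for stronger inhibition), and a fourth awaits measurement. Compound 1, `Cc1ncnc2c1c(I)cn2[C@@H]1O[C@H](CO)[C@@H](O)[C@H]1O`, gives 4080 nM in this assay. For compound 2, `COc1ncnc2c1c(-c1ccccc1)cn2[C@@H]1O[C@H](CO)[C@@H](O)[C@H]1O`, this assay reports only a limit, > 20000 nM. For compound 3, `CNc1ncnc2c1c(I)cn2[C@@H]1O[C@H](CO)[C@@H](O)[C@H]1O`, this assay likewise reports only a limit, > 20000 nM. Compound 3 therefore stands at the weak end of what is shown: the step of an at least 4.9-fold higher number from compound 1 to compound 3 (0.69 log units; beyond the scatter) marks it as a clearly weaker inhibitor than compound 1, and compound 3 rests at the limit of > 20000 nM in this assay, at which 2 of the 3 values shown sit.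

Compound 4, `COc1ncnc2c1c(I)cn2[C@@H]1O[C@H](CO)[C@@H](O)[C@H]1O`, is the next compound. Relative to compound 3 the change is methoxy in place of methylamino on an aromatic carbon. Within the data shown here, no measured step covers this exact exchange of methoxy for methylamino at this position. Among the measured compounds shown here, the only measured step, an at least 4.9-fold higher number from compound 1 to compound 3 (0.69 log units; beyond the scatter), shows that changing the group at this same place can move the number beyond the scatter, but it ran toward weaker inhibition and ended at a limit. Compound 2, which also carries a methoxy group, gave only a limit in this assay. Compound 4 is expected to stay weak, with a step estimated as an at least 1.6-fold lower number from compound 3 to compound 4 (0.22 log units; that floor lies within the scatter). The value for compound 4 is estimated at 12000 nM, within a range of 2500 nM to 50000 nM.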

Compound 4, half-maximal inhibitory concentration: 14300 nM
Estimate against measurement, compound 4: 1.2-fold (0.08 log units) below; measured number inside the range.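

In this assay, methoxy in place of methyl on an aromatic carbon gives a 3.5-fold higher number from compound 1 to compound 4 (0.54 log units; beyond the scatter), so methoxy joins methylamino as a second group at this place that reads clearly weaker than the methyl of compound 1. Unlike compound 3, compound 4 gives a true number rather than a limit, and the exchange of methylamino for methoxy reads as an at least 1.3-fold lower number from compound 3 to compound 4 (0.14 log units; that floor lies within the scatter), while iodo in place of phenyl, with methoxy kept, reads as an at least 1.3-fold lower number from compound 2 to compound 4 (0.14 log units; that floor lies within the scatter). Neither floor separates the compounds, and the real size of both steps stays unknown because compound 2 and compound 3 each rest on a limit: the limit of > 20000 nM in this assay, at which 2 of the 4 values shown sit.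

The compounds shown leave open whether a plain amine, a longer chain such as ethyl, or a chlorine atom at this place would match the methyl of compound 1 or fall away as methoxy and methylamino do. They also leave open how compound 3 and compound 4 truly rank, since that needs a true number for compound 3.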